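The source may report more compounds than this note shows. Statements on the series, on what has been measured and on what is new or still open speak of the compounds shown alone.

Three compounds share one core and differ only in the aryl group carried on the sulfonyl sulfur. In an assay on HeLa cells for binding affinity to 5-hydroxytryptamine receptor 6 (Homo sapiens) (on this read-out higher numbers stand for weaker inhibition and lower numbers for stronger inhibition), compound 1 `COc1ccc(NS(=O)(=O)c2ccc(Br)cc2)cc1N1CCN(C)CC1` gives 5.01 nM, compound 2 `COc1ccc(NS(=O)(=O)c2cc(I)ccc2C)cc1N1CCN(C)CC1` gives 1 nM, and compound 3 `COc1ccc(NS(=O)(=O)c2ccccc2)cc1N1CCN(C)CC1` gives 10 nM. Compound 3 and compound 1 lie within the usual scatter of each other (a 2.0-fold higher number from compound 1 to compound 3 (0.30 log units; within the scatter)), whereas compound 2 sits a clear step below compound 3 (a 10-fold higher number from compound 2 to compound 3 (1.00 log units; beyond the scatter)).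

Compound 4 `COc1ccc(NS(=O)(=O)c2cccc(I)c2)cc1N1CCN(C)CC1` has not yet been measured in this assay. It differs from compound 3 by iodo in place of hydrogen on an aromatic carbon. Going by the values given here, two measured steps bear on this change. The step of a 2.0-fold higher number from compound 1 to compound 3 (0.30 log units; within the scatter) shows that taking a halogen off the aryl ring moved the number only within the scatter. The step of a 10-fold higher number from compound 2 to compound 3 (1.00 log units; beyond the scatter) shows that removing iodo together with methyl raised the number clearly. The data do not separate the part of iodo alone from that of methyl. A small downward step is therefore expected for compound 4, a 2.9-fold lower number from compound 3 to compound 4 (0.46 log units; beyond the scatter). Compound 4 is estimated at 3.5 nM, with a range from 1.5 nM to 8 nM.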

Compound 4, inhibition constant: 0.794 nM
For compound 4 the middle estimate is 4.4-fold (0.64 log units) above the measured one; measured number below the stated range.
By their numbers in this assay, from the lowest: compounds 4 and 2 (each within the scatter of the next); then compounds 1 and 3 (each within the scatter of the next).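

In this assay, going by these compounds alone, the iodo group on its own, meta to a large group, carries the gain that the earlier compounds could not assign between iodo and methyl (a 13-fold lower number from compound 3 to compound 4 (1.10 log units; beyond the scatter)). Methyl adds no readable change once iodo is present, as hydrogen in its place stays within the scatter (a 1.3-fold lower number from compound 2 to compound 4 (0.10 log units; within the scatter)). The step from the bromo compound is also clear (a 6.3-fold lower number from compound 1 to compound 4 (0.80 log units; beyond the scatter)), but it changes the halogen and its place together, so the two cannot be told apart.

The compounds shown leave open whether bromo or chloro at the place of this iodo would give the same step, and whether a methoxy group or an amine there would keep it. No measured evidence bears on what lies behind this step.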